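The compounds below may be only part of what the source reports. "The series", "measured", "known", "first", "only" and "open" are said of these compounds alone.

Three analogues of the shared core differ only in the group on the urea carbonyl. Compound 1 `COCCCNC(=O)Nc1cc2c(Nc3ccc(F)c(Cl)c3)ncnc2cc1O[C@H]1CCOC1` gives 4100 nM in a functional assay on A-431 cells (Homo sapiens) for antiproliferative activity, read by sulforhodamine B assay, with a stated time of 72 h; on this read-out lower numbers stand for stronger inhibition and higher numbers for weaker inhibition; compound 2 `CN(C)CCN(C)C(=O)Nc1cc2c(Nc3ccc(F)c(Cl)c3)ncnc2cc1O[C@H]1CCOC1` gives 450 nM in this assay, and compound 3 `CCN(CC)CCN(C)C(=O)Nc1cc2c(Nc3ccc(F)c(Cl)c3)ncnc2cc1O[C@H]1CCOC1` gives 481 nM. Compound 3 stands second highest of the three: a 1.1-fold higher number from compound 2 to compound 3 (0.03 log units; within the scatter), while an 8.5-fold lower number from compound 1 to compound 3 (0.93 log units; beyond the scatter). Compound 4 `O=C(Nc1cc2c(Nc3ccc(F)c(Cl)c3)ncnc2cc1O[C@H]1CCOC1)N1CCC(F)CC1` differs from compound 3 by 4-fluoropiperidin-1-yl in place of (2-(diethylamino)ethyl)(methyl)amino on a carbonyl carbon. For the measured compounds named here, no measured step makes exactly this change; the steps that bear on the carbonyl substituent are a 9.1-fold lower number from compound 1 to compound 2 (0.96 log units; beyond the scatter) and an 8.5-fold lower number from compound 1 to compound 3 (0.93 log units; beyond the scatter), both starting from the (3-methoxypropyl)amino group of compound 1, which like the entering 4-fluoropiperidin-1-yl lacks the aminoethyl chain. Compound 4 is therefore expected to move back toward the number of the methoxypropyl analogue, with a 4.2-fold higher number from compound 3 to compound 4 (0.62 log units; beyond the scatter). Compound 4 is estimated at 2000 nM, range 600 nM to 6500 nM.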

Compound 4, half-maximal inhibitory concentration: 3040 nM
For compound 4 the middle estimate is 1.5-fold (0.18 log units) below the measured one; the range from low to high includes it.
By their numbers in this assay, from the lowest: compounds 2 and 3 (each within the scatter of the next); then compounds 4 and 1 (each within the scatter of the next).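

In this assay, 4-fluoropiperidin-1-yl on the carbonyl carbon does not keep the level of the compounds with the aminoethyl chain: a 6.3-fold higher number from compound 3 to compound 4 (0.80 log units; beyond the scatter), and a 6.8-fold higher number from compound 2 to compound 4 (0.83 log units; beyond the scatter). Set against the (3-methoxypropyl)amino group, the ring gives a 1.3-fold lower number from compound 1 to compound 4 (0.13 log units; within the scatter), so two quite different groups without that chain stand together among these four compounds. Nothing measured here accounts for this split.

Open, going by these compounds, is whether 4-(dimethylamino)piperidin-1-yl, which carries a ring and an amine together, would return to the level of compound 2.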